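A few compounds are considered here, and "the series" means these few. Any claim that something is new, unique, unknown or untested is made for them only; others in the source may bear on it.

The series shares a five-membered non-aromatic ring with one nitrogen and one sulfur, carrying an aryl group on its amide-type nitrogen. Compound 1 `COc1ccc(C)cc1N1C(=O)CSC1c1cccc(C(=O)NCCCCc2ccccc2)c1` gives 29% in a functional assay on 143B cells (Homo sapiens) for inhibition, read by CCK-8 assay, with a stated time of 72 h, tested at 1 uM; a higher number here means more inhibition at the concentration tested (going by the name of the read-out), a lower number less inhibition. Compound 2 `COc1ccc(F)cc1N1C(=O)CSC1c1cccc(C(=O)NCCCCc2ccccc2)c1` gives 62% in this assay, and compound 3 `O=C(NCCCCc1ccccc1)c1cccc(C2SCC(=O)N2c2cccc(F)c2)c1` gives 63%. Compound 2 thus stands second highest of the three numbers: its nearest neighbour is compound 3, with a number 1 percentage points higher from compound 2 to compound 3 (within the scatter), and its furthest is compound 1, with a number 33 percentage points higher from compound 1 to compound 2 (beyond the scatter).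

Compound 4 `O=C(NCCCCc1ccccc1)c1cccc(C2SCC(=O)N2c2ccccc2F)c1` has not yet been measured in this assay. It differs from compound 2 by 2-fluorophenyl in place of 5-fluoro-2-methoxyphenyl on an amide-type nitrogen in a ring.

Within the data shown here, two measured steps bear on this change. The step of a number 34 percentage points higher from compound 1 to compound 3 (beyond the scatter) shows that a fluorophenyl on the ring nitrogen can carry a large gain over the 2-methoxy-5-methylphenyl of compound 1. The step of a number 1 percentage points higher from compound 2 to compound 3 (within the scatter) shows that, once fluorine is present, removing the methoxy changes nothing beyond the scatter. Among the measured compounds shown here, no measured pair distinguishes 2-fluorophenyl from 3-fluorophenyl, so that part of the change is untested. The expectation is therefore a step of about a number 4 percentage points lower from compound 2 to compound 4 (within the scatter), within the scatter, with a wide range to cover the untested part. Compound 4 is estimated at 58%, between 40% and 72%.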

Compound 4, a percentage reported as inhibition, at one concentration (the size of the read-out at that concentration, not a potency): 59%
Estimate against measurement, compound 4: 1 percentage points below, and the stated range covers the measured number.
By their numbers in this assay, from the lowest: compound 1; then compounds 4, 2 and 3 (each within the scatter of the next).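

Among these compounds, the step of a number 4 percentage points lower from compound 3 to compound 4 (within the scatter) gives the first direct comparison of 2-fluorophenyl with 3-fluorophenyl on the ring nitrogen, and in this assay the two groups cannot be told apart. The step of a number 3 percentage points lower from compound 2 to compound 4 (within the scatter) likewise leaves 2-fluorophenyl and 5-fluoro-2-methoxyphenyl unseparated, so compounds 2, 3 and 4 now form a group of three fluorinated aryl variants whose numbers lie within the scatter of one another. The step of a number 30 percentage points higher from compound 1 to compound 4 (beyond the scatter) shows that 2-fluorophenyl also keeps a gain beyond the scatter over the 2-methoxy-5-methylphenyl of compound 1, so this gain is not confined to a single placement of the fluorine among the listed compounds.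

No measurement on hand explains why these aryl groups behave alike or why compound 1 stands apart. Open questions are whether an unsubstituted phenyl, a chlorophenyl or a pyridyl group on the ring nitrogen would stay at this level, and whether the three fluorinated compounds, seen here at a single concentration, would still be indistinguishable across a full concentration range.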